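The source may hold more compounds than are shown below. What is called first, only, known or untested is meant among the compounds shown, and "the series" means these compounds.

Working notes on the series. The shared core is that of compound 1 `COc1nc2ccccc2cc1/C=C/c1noc(-c2ccccc2)n1`; in an ADME assay on HepG2 cells (Homo sapiens) for cytotoxicity, read by sulforhodamine B assay, with a stated time of 48 h (a lower number here means that less compound is tolerated, a higher number that more compound is tolerated), compound 1 gives no number but a limit, > 240000 nM. Compound 2 `COc1nc2ccccc2cc1/C=C/c1noc(-c2ccccc2C)n1` carries a methyl in place of hydrogen on an aromatic carbon of the phenyl; in this assay compound 2 likewise gives a limit, > 230000 nM. Compound 3 `COc1nc2ccccc2cc1/C=C/c1noc(-c2ccccc2Br)n1` carries a bromo in place of hydrogen on an aromatic carbon; in this assay compound 3 also gives a limit, > 195000 nM. Because of the limits (the limit of > 195000 nM in this assay, at which 1 of the 3 values shown sits), the limit of > 230000 nM in this assay, at which 1 of the 3 values shown sits, and (the limit of > 240000 nM in this assay, at which 1 of the 3 values shown sits), the steps a step that the two limits leave unreadable from compound 1 to compound 2, a step that the two limits leave unreadable from compound 1 to compound 3 and a step that the two limits leave unreadable from compound 2 to compound 3 cannot be read. Compound 1 therefore stands at a limit, and the two other values stand at limits as well; no order among the three can be drawn.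

Compound 4 `COc1nc2ccccc2cc1/C=C/c1noc(C)n1` differs from compound 1 by methyl in place of phenyl on an aromatic carbon. The measured steps all alter the phenyl that leaves here, and all three are unreadable, so they give no size and no direction for this change in this assay. With every measured value at a limit, the step of a number no higher from compound 1 to compound 4 (the limit leaves the size open) is expected to show nothing beyond the scatter. Compound 4 is expected at 240000 nM, in the range 100000 nM to 500000 nM, most likely again reported only as a limit.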

Compound 4, half-maximal cytotoxic concentration: > 300000 nM
Compound 4: a limit, no number (the forecaster's own chance of this, stated with the estimate: 80%); middle value at least 1.2-fold (0.09 log units) from the limit.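

In this assay compound 4 gives > 300000 nM, again a limit and not a number. For the compounds shown here, compound 1, compound 2 and compound 3 also stand at limits, and no step from any of them to compound 4 can be read. The compounds shown leave open at what concentration any of the four becomes cytotoxic, and whether methyl in place of phenyl changes this at all.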